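A cyclohexyl swap in a narrow three-compound series

The compounds below may be only part of what the source reports. "The series", "measured", "known", "first", "only" and "open" are said of these compounds alone.

In a functional assay on U-251 cells (Homo sapiens) for inhibition, read by sulforhodamine B assay, with a stated time of 72 h (on this read-out higher numbers stand for an effect only at larger amounts of compound and lower numbers for an effect already at smaller amounts), compound 1 (`O=C(/C=C/c1ccc([N+](=O)[O-])o1)c1ccc(Br)cc1`) gives 21400 nM, compound 2 (`O=C(/C=C/c1ccc([N+](=O)[O-])o1)c1ccc(-n2ccnc2)cc1`) gives 22600 nM and compound 3 (`O=C(/C=C/c1ccc([N+](=O)[O-])o1)c1ccc(N2CCCC2)cc1`) gives 35900 nM. Compound 3 cannot be separated from the other two, since all three values lie within the scatter of one another. Compound 4 (`O=C(/C=C/c1ccc([N+](=O)[O-])o1)c1ccc(C2CCCCC2)cc1`) carries cyclohexyl in place of pyrrolidin-1-yl on an aromatic carbon. For the measured compounds named here, three measured steps bear on this place, and all stay within the scatter: a 1.1-fold higher number from compound 1 to compound 2 (0.02 log units; within the scatter), a 1.7-fold higher number from compound 1 to compound 3 (0.22 log units; within the scatter) and a 1.6-fold higher number from compound 2 to compound 3 (0.20 log units; within the scatter). Going by the values given here, no cyclohexyl group has yet been measured here, so no step beyond the scatter is expected in this assay. The estimated step is a 1.3-fold lower number from compound 3 to compound 4 (0.11 log units; within the scatter). For compound 4 the expected value is 28000 nM, with an estimated range of 13000 nM to 55000 nM.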

Compound 4, half-maximal effective concentration: 4400 nM
For compound 4 the middle estimate is 6.4-fold (0.80 log units) above the measured one, and the stated range ends above it.
By their numbers in this assay, from the lowest: compound 4; then compounds 1, 2 and 3 (each within the scatter of the next).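

In this assay this place first separates compounds, as cyclohexyl gives steps beyond the scatter against all three earlier groups (an 8.2-fold lower number from compound 3 to compound 4 (0.91 log units; beyond the scatter); a 5.1-fold lower number from compound 2 to compound 4 (0.71 log units; beyond the scatter); a 4.9-fold lower number from compound 1 to compound 4 (0.69 log units; beyond the scatter)), whereas bromo, 1H-imidazol-1-yl and pyrrolidin-1-yl stayed within it. Cyclohexyl is the only one of the four groups that is a ring of carbon only, but a single compound cannot show that this feature is what counts. Nothing measured here accounts for the step. Going by these compounds, whether phenyl, cyclopentyl or an open chain such as n-hexyl would match cyclohexyl at this place stays open. So does whether a hydroxyl on the cyclohexyl ring would keep the step.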